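The source may hold more compounds than are shown below. What is called first, only, known or untested is meant among the compounds shown, and "the series" means these compounds.

In an ADME assay on HEK293 cells (Homo sapiens) for cytotoxicity, read by MTT assay, with a stated time of 48 h (a higher number here means a weaker inhibitor, a lower number a stronger inhibitor), compound 1 `Cn1c(N)c(-c2nc3ccccc3[nH]2)c2nc(C#N)c(C#N)nc21` reads > 50000 nM, and this value is a limit of the assay, not a number. Compound 2 `CN(C)CCn1c(N)c(-c2nc3ccccc3[nH]2)c2nc(C#N)c(C#N)nc21` gives 9730 nM. Compound 3 `N#Cc1nc2c(-c3nc4ccccc4[nH]3)c(N)n(CCN3CCCC3)c2nc1C#N` gives 18300 nM, and the step between these two, a 1.9-fold higher number from compound 2 to compound 3 (0.27 log units; within the scatter), stays within the scatter. Compound 4 `N#Cc1nc2c(-c3nc4ccccc4[nH]3)c(N)n(CCO)c2nc1C#N` differs from compound 3 by hydroxy in place of pyrrolidin-1-yl on a saturated chain carbon, two bonds along the chain from an aromatic nitrogen. Going by the values given here, no measured step makes this exact exchange. The closest evidence comes from the steps that introduce the dimethylamino and pyrrolidin-1-yl chains on compound 1, namely an at least 5.1-fold lower number from compound 1 to compound 2 (0.71 log units; beyond the scatter) and an at least 2.7-fold lower number from compound 1 to compound 3 (0.43 log units; beyond the scatter). Both run to lower numbers beyond the scatter, and both are bounded on one side by the limit. Compound 4 keeps a chain of the same length but gives up the pyrrolidin-1-yl, so part of an at least 2.7-fold lower number from compound 1 to compound 3 (0.43 log units; beyond the scatter) is expected to be undone. The step expected is therefore a 1.8-fold higher number from compound 3 to compound 4 (0.26 log units; within the scatter), toward a higher number. Compound 4 is estimated at 33000 nM, with an expected range of 15000 nM to 70000 nM.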

Compound 4, half-maximal inhibitory concentration: > 50000 nM
Compound 4 was reported as a limit (the forecaster's own chance of this, stated with the estimate: 35%); at least 1.5-fold (0.18 log units) between middle value and limit.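

In this assay, on a saturated chain carbon, two bonds along the chain from an aromatic nitrogen, hydroxy in place of pyrrolidin-1-yl gives an at least 2.7-fold higher number from compound 3 to compound 4 (0.43 log units; beyond the scatter), and hydroxy in place of dimethylamino gives an at least 5.1-fold higher number from compound 2 to compound 4 (0.71 log units; beyond the scatter). The earlier compounds could not separate the chain from the group at its end, whereas compound 4 shows that, among the compounds shown, the lower numbers of compound 2 and compound 3 do not come with the chain alone: they are lost when a 2-hydroxyethyl chain takes the place of the amine-bearing chains. Compound 1 and compound 4 both stand at a limit, not a number, so the step between them cannot be read: the limit of > 50000 nM in this assay, at which 2 of the 4 values shown sit.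

As far as these compounds go, what stays open is whether another amine at the chain's end, such as morpholine, would keep the lower numbers. A longer chain carrying dimethylamino is equally untested by the compounds shown.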